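Trimethylpiperazine in place of methylpiperazine on the shared core

A few compounds are considered here, and "the series" means these few. Any claim that something is new, unique, unknown or untested is made for them only; others in the source may bear on it.

In a functional assay on CCRF-CEM cells for antagonist activity at C-X-C chemokine receptor type 4 (Homo sapiens), read by calcium flux, with stated times of 25 min and 90 s (on this read-out higher numbers stand for weaker inhibition and lower numbers for stronger inhibition), three compounds on a shared core have been measured. Compound 1 `CN(C[C@H]1Cc2c(cccc2N2CCN(C3COC3)CC2)CN1)[C@H]1CCCc2cccnc21` gives 381 nM; compound 2 `CN(C[C@H]1Cc2c(cccc2N2CCN3CCC[C@@H]3C2)CN1)[C@H]1CCCc2cccnc21` gives 3.59 nM; compound 3 `CN1CCN(c2cccc3c2C[C@H](CN(C)[C@H]2CCCc4cccnc42)NC3)CC1` gives 29.6 nM, the second highest of the three numbers. The steps around compound 3 are large: a 13-fold lower number from compound 1 to compound 3 (1.11 log units; beyond the scatter), and an 8.2-fold higher number from compound 2 to compound 3 (0.92 log units; beyond the scatter). Compound 4 `C[C@@H]1CN(c2cccc3c2C[C@H](CN(C)[C@H]2CCCc4cccnc42)NC3)C[C@H](C)N1C` differs from compound 3 by 3,4,5-trimethylpiperazin-1-yl in place of 4-methylpiperazin-1-yl on an aromatic carbon. For the measured compounds named here, no measured step matches this change exactly. Going by the values given here, the nearest is the one to compound 2, where a larger ring system with two nitrogens on the same aromatic carbon gave a lower number than the plain methylpiperazine of compound 3 (an 8.2-fold higher number from compound 2 to compound 3 (0.92 log units; beyond the scatter) read in reverse). The extra methyls of compound 4 add carbons in that direction, so a modestly lower number than that of compound 3 is expected, though smaller than the step to compound 2. Compound 4 is therefore expected to give 12 nM in this assay, with a range of 4 nM to 40 nM, a step of a 2.5-fold lower number from compound 3 to compound 4 (0.39 log units; beyond the scatter).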

Compound 4, half-maximal inhibitory concentration: 14.1 nM
Beside the measured number, compound 4's estimate is 1.2-fold (0.07 log units) below it, within the range that was stated.
By their numbers in this assay, from the lowest: compound 2; then compound 4; then compound 3; then compound 1.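

In this assay, 3,4,5-trimethylpiperazin-1-yl in place of 4-methylpiperazin-1-yl on the aromatic carbon moves the number modestly lower (a 2.1-fold lower number from compound 3 to compound 4 (0.32 log units; beyond the scatter)), so this position accepts ring methyls on the piperazine without loss. The group of compound 2, with its five-membered ring, still gives the lowest number of the set (a 3.9-fold higher number from compound 2 to compound 4 (0.59 log units; beyond the scatter)), while the new group stands far lower than 4-(oxetan-3-yl)piperazin-1-yl (a 27-fold lower number from compound 1 to compound 4 (1.43 log units; beyond the scatter)). No evidence is available to explain these steps.

The compounds shown do not separate the effect of the ring methyls from that of their defined stereocentres. They also leave open how a 4-ethylpiperazin-1-yl group or a morpholine ring would compare at this position.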